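This account rests on a few compounds, and the source may have more. Where it says the series, first, only, none or still open, it means among the compounds named here.

Of the compounds shown here, two have been measured, both on the shared core with an aryl amide. Compound 1 `O=C(Nc1cc(-c2ccccc2)nn1-c1ccccc1)c1cccc(Cl)c1` carries 3-chlorophenyl on the carbonyl carbon, and in an assay on CHO cells with metabotropic glutamate receptor 5 (Homo sapiens) as the target (on this read-out higher numbers stand for an effect only at larger amounts of compound and lower numbers for an effect already at smaller amounts), compound 1 gives 40 nM. For the measured compounds named here, compound 2 `O=C(Nc1cc(-c2ccccc2)nn1-c1ccccc1)c1cnccn1` carries pyrazin-2-yl in that place; in this assay compound 2 gives 200 nM, the highest of the two numbers, with compound 1 as its only neighbour. Going by the values given here, the one measured step is a 5.0-fold higher number from compound 1 to compound 2 (0.70 log units; beyond the scatter). Compound 3 `O=C(Nc1cc(-c2ccccc2)nn1-c1ccccc1)c1cccc(F)c1` is not yet measured; it differs from compound 2 by 3-fluorophenyl in place of pyrazin-2-yl on a carbonyl carbon. This change runs close to the reverse of the measured step, with 3-fluorophenyl standing where compound 1 has 3-chlorophenyl. For compound 3 the expected step is a 3.3-fold lower number from compound 2 to compound 3 (0.52 log units; beyond the scatter), a lower number, because compound 1 with 3-chlorophenyl already gave 40 nM. The estimate for compound 3 in this assay is 60 nM, with a range of 20 nM to 180 nM.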

Compound 3, half-maximal effective concentration: 20 nM
Estimate against measurement, compound 3: 3.0-fold (0.48 log units) above, within the range that was stated.
By their numbers in this assay, from the lowest: compounds 3 and 1 (each within the scatter of the next); then compound 2.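

In this assay, 3-fluorophenyl in place of pyrazin-2-yl on a carbonyl carbon gives a 10-fold lower number from compound 2 to compound 3 (1.00 log units; beyond the scatter) and so confirms, with a second halogen-bearing phenyl group, the separation from compound 2 that previously rested on compound 1 alone. Fluoro in place of chloro on an aromatic carbon gives a 2.0-fold lower number from compound 1 to compound 3 (0.30 log units; within the scatter) and so does not separate the two halogens in this read-out. At this position, the choice between 3-chlorophenyl and 3-fluorophenyl therefore matters less on these numbers than the choice between either group and pyrazin-2-yl.

Still open, as far as these compounds go, is whether the halogen is needed at all, since plain phenyl or a phenyl group carrying an amine or a methoxy group does not appear here. From the compounds shown here alone, the rest of the shared core also stays unchanged across all three compounds, so its contribution remains unknown. No supporting measurement bears on what lies behind these differences.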